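From a nitrile to a diamine on a shared core

The source may hold more compounds than are shown below. What is called first, only, known or untested is meant among the compounds shown, and "the series" means these compounds.

Of the compounds shown here, three have been measured in a functional assay on PLC5 cells (Homo sapiens) for inhibition, read by MTT assay, with a stated time of 24 h; on this read-out higher numbers stand for weaker inhibition and lower numbers for stronger inhibition. Compound 1 `N#Cc1ccc(Oc2ccc(CNC(=O)Nc3ccc(Cl)c(C(F)(F)F)c3)cc2)cc1` gives 2100 nM. Compound 2 `N#Cc1ccc(Oc2cccc(NCc3cccc(OC(F)(F)F)c3)c2)cc1` gives only a limit, > 15000 nM. Compound 3 `N#Cc1ccc(Oc2cccc(NC(=O)c3ccccc3)c2)cc1` likewise gives only a limit, > 15000 nM. Compound 2 thus stands at the edge of what this assay reports, a position it shares with compound 3, as the limit of > 15000 nM in this assay, at which 2 of the 3 values shown sit, records. The unmeasured compound 4 `Nc1ccc(Oc2cccc(NCc3cccc(OC(F)(F)F)c3)c2)cc1N` differs from compound 2 in one place: 3,4-diaminophenyl in place of 4-cyanophenyl on an oxygen on an aromatic ring. Going by the values given here, no measured pair shows what such a change does here, and the numbers point in no particular direction. The step in this assay is expected to stay within the scatter: a step that the limit leaves unreadable from compound 2 to compound 4. Compound 4 is estimated at 20000 nM, within a range from 6000 nM to 60000 nM, and is expected most likely to be reported again only as a limit.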

Compound 4, half-maximal inhibitory concentration: > 15000 nM
Compound 4 gave a limit, no number; the forecaster's own chance of this, stated with the estimate: 70%; the middle value is on the limit's open side.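

Going by these compounds alone, compound 2 and compound 4 are both reported only as limits, not numbers, so no step between them can be read. The compounds shown leave open whether 3,4-diaminophenyl in place of 4-cyanophenyl changes inhibition at all.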